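Inversion of one ring stereocentre: compound 2 to compound 3

A few compounds are considered here, and "the series" means these few. Any claim that something is new, unique, unknown or untested is made for them only; others in the source may bear on it.

Measured compounds
- compound 1, `Nc1ccccc1NC(=O)/C=C/c1cn([C@@H]2C[C@@H](C(=O)O)N(CCCc3ccccc3)C2)nn1`: < 10%
- compound 2, `Nc1ccccc1NC(=O)/C=C/c1cn([C@H]2C[C@@H](CO)N(CCCc3ccccc3)C2)nn1`: 19%

In an assay on cells for inhibition of histone deacetylase 11 (Homo sapiens), read by fluorescence, with stated times of 3 h and 30 min, tested at 2 uM, in the presence of a further agent that is not named here (on this read-out lower numbers stand for less inhibition and higher numbers for more inhibition at the one concentration tested (going by the name of the read-out)), compound 1 gives < 10%, which is a limit of the assay and not a number. Within the data shown here, in the same assay compound 2 gives 19%, the only plain number in the set, so compound 2 stands as the one measured point against which a change can be read, while the value of compound 1 sits at the limit of < 10% in this assay, at which 1 of the 2 values shown sits.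

Compound 3, `Nc1ccccc1NC(=O)/C=C/c1cn([C@@H]2C[C@@H](CO)N(CCCc3ccccc3)C2)nn1`, is not yet measured. the two compounds have the same atoms and bonds and differ only in configuration as drawn: 1 of 3 stereo elements differ; a stereocentre at a saturated ring carbon is drawn S in compound 2 and R in compound 3

Among the measured compounds shown here, no step between two measured compounds is available in this assay, so nothing in the data tells what the inversion of the stereocentre at a saturated ring carbon does here. With the two measured values so close together and one of them only a limit, the step from compound 2 to compound 3 is expected to be small, in either direction, and within the usual scatter: a number 4 percentage points lower from compound 2 to compound 3 (within the scatter). Compound 3 is estimated to give 15% in this assay, with a range from 4% to 30%.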

Compound 3, a percentage reported as inhibition, at one concentration (the size of the read-out at that concentration, not a potency): 13%
Compound 3: middle estimate off by 2 percentage points, on the high side; the measured number falls inside the stated range.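

In this assay the inversion of the saturated ring carbon comes to a number 6 percentage points lower from compound 2 to compound 3 (within the scatter), the first step read at this position, and it can be set down to configuration alone: the fact that compounds 2 and 3 differ only in the configuration as drawn

Compound 1 gives < 10%, which is a limit of the assay and not a number.

Hydroxymethyl in place of carboxy on the saturated ring carbon comes to a number at least 3 percentage points higher from compound 1 to compound 3 (that floor lies within the scatter), so this swap is read only as a floor and shows no change beyond the scatter: the limit of < 10% in this assay, at which 1 of the 3 values shown sits.

Open, on these data alone, is whether an amine or a methyl ester in place of hydroxymethyl on this ring carbon would give a step beyond the scatter. Also open, as far as these compounds go, is whether the two configurations would stay as close with a carboxylic acid at this position, or with a longer chain on the ring nitrogen.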